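Nitro in place of chloro: expected effect of compound 4

The source may report more compounds than this note shows. Statements on the series, on what has been measured and on what is new or still open speak of the compounds shown alone.

Compound 1 `O=C(Cn1c(=O)oc2cc([N+](=O)[O-])ccc21)Nc1ccccn1`: 38.6%
Compound 2 `O=C(Cn1c(=O)oc2cc(Cl)ccc21)NCc1cccs1`: 20.3%
Compound 3 `O=C(Cn1c(=O)oc2cc(Cl)ccc21)Nc1ccccc1`: 15.8%

These three values come from an ADME assay on RAW264.7 cells (Mus musculus) for cytotoxicity, read by MTT assay, with a stated time of 72 h, tested at 50 uM; a lower number here means a weaker effect, a higher number a stronger effect of the compound at the concentration tested. Compound 3 gives the lowest number of the three, though its gap to compound 2, a number 4.5 percentage points lower from compound 2 to compound 3 (within the scatter), lies within the scatter; only compound 1 stands clearly higher. Compound 4 `O=C(Cn1c(=O)oc2cc([N+](=O)[O-])ccc21)Nc1ccccc1` differs from compound 3 by nitro in place of chloro on an aromatic carbon. Among the measured compounds shown here, no measured pair differs by exactly this change, so no step speaks to it directly; the one available step, a number 4.5 percentage points lower from compound 2 to compound 3 (within the scatter), concerns the amide side and is small. For the measured compounds named here, compound 1, the only nitro compound, gives 38.6%, but it also carries a different amide substituent. For compound 4 a moderate rise, a number 12.2 percentage points higher from compound 3 to compound 4 (beyond the scatter), is therefore expected, giving an estimated 28% with a range from 10% to 46%.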

Compound 4, a percentage reported as inhibition, at one concentration (the size of the read-out at that concentration, not a potency): 18%
For compound 4 the middle estimate is 10 percentage points above the measured one; the range from low to high includes it.
By their numbers in this assay, from the lowest: compounds 3, 4 and 2 (each within the scatter of the next); then compound 1.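

With a number 2.2 percentage points higher from compound 3 to compound 4 (within the scatter) in this assay nitro in place of chloro on this aromatic carbon makes no clear difference. Among the compounds shown here, the step of a number 20.6 percentage points lower from compound 1 to compound 4 (beyond the scatter) comes with phenyl in place of pyridin-2-yl on the amide-type nitrogen as the only change, so the high reading of compound 1 goes with its pyridin-2-yl group and not with nitro alone. Nothing available explains either step.

On these data alone, whether an amine or a carboxylic acid on this carbon would read like chloro and nitro remains open. Also open, as far as these compounds go, is whether pyridin-2-yl would raise the reading with chloro on the core.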